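Methyl for Isopropyl on the Fused Core of Compound 2

The source may report more compounds than this note shows. Statements on the series, on what has been measured and on what is new or still open speak of the compounds shown alone.

Measured so far:
Compound 1, `Cn1cc(-c2nc3c(-c4ccnc(OC5CC5)c4)cnn3cc2OCC(C)(C)O)cn1`: 81%
Compound 2, `COc1cc(-c2cnn3cc(OC)c(C(C)C)nc23)ccn1`: 14%
Compound 3, `COc1cn2ncc(-c3ccnc(OC(C)(C)C)c3)c2nc1-c1cnn(C)c1`: 61%

In an ADME assay on microsomes from liver (Rattus norvegicus) for metabolic stability, with a stated time of 60 min, tested at 1 uM (on this read-out higher numbers stand for a more stable compound and lower numbers for a less stable compound), compound 1 gives 81% and compound 3 gives 61%. Compound 2 sits at the bottom of these three numbers with 14%; its nearest neighbour is compound 3, whose value lies well above it, beyond the scatter, and compound 1 lies further above still, also beyond the scatter. Compounds 1 and 3 differ from compound 2 in several places at once, so their values show only where they stand, not what any single change does.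

The step to compound 4, `COc1cc(-c2cnn3cc(OC)c(C)nc23)ccn1`, alters compound 2 in one place: methyl in place of isopropyl on an aromatic carbon. The methyl sits on the aromatic carbon next to the ring nitrogen, ortho to the methoxy group, where the isopropyl of compound 2 stood. No pair among the measured compounds isolates this change, so nothing in the shown numbers fixes its size.

Because compound 2 gives only 14%, there is more room upward than downward, and a moderate rise is expected for compound 4, of about a number 21 percentage points higher from compound 2 to compound 4 (beyond the scatter) in this assay. Compound 4 is thus estimated at 35%, within a range from 12% to 65%.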

Compound 4, percent of the compound remaining: 13%
Estimate against measurement, compound 4: 22 percentage points above; measured number inside the range.
By their numbers in this assay, from the lowest: compounds 4 and 2 (each within the scatter of the next); then compound 3; then compound 1.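

Methyl in place of isopropyl on the aromatic carbon next to the ring nitrogen gives the first reading of a single change at this position: in this assay it amounts to a number 1 percentage points lower from compound 2 to compound 4 (within the scatter). On this scaffold, then, the choice between these two alkyl groups does not separate the compounds, and the pair stays at the low end of the read-out, with compound 2 at 14% and compound 4 at 13%. Nothing available speaks to why the exchange leaves the two compounds indistinguishable.

The compounds shown leave open whether a group of another kind on this aromatic carbon, such as an amine, a carboxylic acid or a longer chain, would give a number beyond the scatter from that of compound 2. They also leave open whether methyl in place of isopropyl would read the same way alongside different groups elsewhere on the shared core, since this one pair holds the methoxy groups of compound 2 fixed.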